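The source may report more compounds than this note shows. Statements on the series, on what has been measured and on what is new or still open speak of the compounds shown alone.

Compound 1 `Cc1ccc(S(=O)(=O)Oc2ccccc2/C=C(\C#N)C(=O)Nc2nnc(C)s2)cc1` gives 33%
Compound 2 `Cc1ccc(S(=O)(=O)Oc2cccc(/C=C(\C#N)C(=O)Nc3nnc(-c4ccccc4Cl)s3)c2)cc1` gives 44%

In a functional assay on RS4-11 cells (Homo sapiens) for inhibition, read by CCK-8 assay, with a stated time of 48 h, tested at 20 uM (a higher number here means more inhibition of growth at the concentration tested, a lower number less inhibition of growth), compound 1 stands lower of the two, and compound 2 lies above it by more than the scatter. Compound 3 `Cc1ccc(S(=O)(=O)Oc2ccccc2/C=C(\C#N)C(=O)Nc2nnc(Cc3cccc4ccccc34)s2)cc1` departs from compound 1 by one change: naphthalen-1-yl in place of hydrogen on a saturated chain carbon bound to an aromatic carbon. For the measured compounds named here, no measured pair differs in one place only, so the expectation rests on thin ground. The expected change is a number 12 percentage points higher from compound 1 to compound 3 (beyond the scatter), a moderate rise. Compound 3 is estimated at 45%, with an expected range from 22% to 72%.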

Compound 3, percent growth inhibition at one concentration: 73%
The estimate for compound 3 lay 28 percentage points below the measured number; the whole stated range lies below it.
By their numbers in this assay, from the lowest: compound 1; then compound 2; then compound 3.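

In this assay, for the compounds shown here, the change from methyl to (naphthalen-1-yl)methyl gives a number 40 percentage points higher from compound 1 to compound 3 (beyond the scatter), the first comparison here that differs in one place only. It shows that a saturated chain carbon bound to an aromatic carbon can carry naphthalen-1-yl, with its 10 heavy atoms, and that growth inhibition rises rather than falls. Nothing available accounts for this rise. Going by these compounds, it remains open whether both aromatic rings are needed, which a phenyl or a cyclohexyl in place of naphthalen-1-yl would address. On these data alone, whether an amine or a carboxylic acid at this place would be accepted also remains open.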